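The compounds below may be only part of what the source reports. "The series", "measured", "known", "first", "only" and "open" are said of these compounds alone.

In a functional assay on MCF7 cells (Homo sapiens) for cytotoxicity (a lower number here means a stronger inhibitor, a higher number a weaker inhibitor), the compounds share one core and differ in the group on an aromatic nitrogen. Compound 1 `COc1ccc(-n2nc(Nc3cc(C)[nH]n3)c3ccccc3c2=O)cc1`, which carries 4-methoxyphenyl there, gives 3600 nM. Compound 2 `Cc1cc(Nc2nn(Cc3cc(F)ccc3F)c(=O)c3ccccc23)n[nH]1` is reported only as a limit, > 30000 nM. Compound 3 `Cc1cc(Nc2nn(C)c(=O)c3ccccc23)n[nH]1` is also reported only as a limit, > 30000 nM. Compound 3 therefore has no number of its own and stands at the limit of > 30000 nM in this assay, at which 2 of the 3 values shown sit.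

Compound 4 `Cc1cc(Nc2nn(Cc3csc(C)n3)c(=O)c3ccccc23)n[nH]1` departs from compound 3 by 2-methyl-1,3-thiazol-4-yl in place of hydrogen on a saturated chain carbon bound to an aromatic nitrogen. Two measured steps, an at least 8.3-fold higher number from compound 1 to compound 2 (0.92 log units; beyond the scatter) and an at least 8.3-fold higher number from compound 1 to compound 3 (0.92 log units; beyond the scatter), are both beyond the scatter, but both start from compound 1, which has no such chain carbon. The step that bears most directly on the change is a step that the two limits leave unreadable from compound 2 to compound 3, so a ring on that carbon has shown no readable effect in this assay. No clear gain is therefore expected, and a result at the limit is the likeliest outcome. The expected change is a number no higher from compound 3 to compound 4 (the limit leaves the size open). For compound 4 the estimate is 30000 nM, with an expected range from 10000 nM to 60000 nM.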

Compound 4, half-maximal inhibitory concentration: > 30000 nM
Compound 4 ended at the assay's limit (the forecaster's own chance of this, stated with the estimate: 70%); the middle value sits exactly at the limit.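

In this assay, within the data shown here, the only new step that can be read is an at least 8.3-fold higher number from compound 1 to compound 4 (0.92 log units; beyond the scatter); the steps from compound 3 to compound 4 and from compound 2 to compound 4 cannot be read, since both ends of each are limits. A five-membered aromatic ring with 2 hetero atoms on the saturated chain carbon bound to an aromatic nitrogen thus leaves compound 4 at the limit, as 2,5-difluorophenyl does in compound 2 and hydrogen does in compound 3, so these three groups cannot be told apart in this assay. Compound 1, with 4-methoxyphenyl on the aromatic nitrogen, is now the only one of the four compounds with a number of its own, while the other three share one reading: the limit of > 30000 nM in this assay, at which 3 of the 4 values shown sit.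

The compounds shown leave open whether the methoxy group of compound 1 matters, which a plain phenyl or a 4-chlorophenyl on the aromatic nitrogen would address. They also leave open whether the saturated chain carbon itself goes with the loss, which a 4-methoxybenzyl group would test against compound 1.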